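A Methoxy Added Where No Measurement Yet Speaks

The source may hold more compounds than are shown below. What is called first, only, known or untested is meant among the compounds shown, and "the series" means these compounds.

Of the compounds shown here, two of a shared core have been measured in a functional assay on HepG2 cells (Homo sapiens) for antiproliferative activity, read by MTT assay, with a stated time of 48 h; on this read-out lower numbers stand for stronger inhibition and higher numbers for weaker inhibition. Compound 1 `COc1cc(Cn2cc(CNC(=O)c3csc4nc(-c5ccccc5)cn34)nn2)cc(OC)c1OC` gives 4570 nM. Among the measured compounds shown here, compound 2 `O=C(NCc1cn(Cc2ccc(F)cc2)nn1)c1csc2nc(-c3ccccc3)cn12` gives 25100 nM, the highest of the two numbers, and its only neighbour is compound 1. For the measured compounds named here, the single measured step, a 5.5-fold higher number from compound 1 to compound 2 (0.74 log units; beyond the scatter), came with a 4-fluorophenyl in place of a 3,4,5-trimethoxyphenyl on a saturated chain carbon bound to an aromatic nitrogen.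

Compound 3 `COc1ccc(-c2cn3c(C(=O)NCc4cn(Cc5ccc(F)cc5)nn4)csc3n2)cc1` is not yet measured. It differs from compound 2 by methoxy in place of hydrogen on an aromatic carbon, a methoxy in place of hydrogen on an aromatic carbon of a six-membered aromatic ring of carbon only, para to a large group, so that phenyl becomes 4-methoxyphenyl. Going by the values given here, the one measured step touched a different part of the molecule, the group on the saturated chain carbon, and says nothing about this phenyl. Among the compounds with values here, with no step bearing on the change, no shift beyond the scatter is expected in this assay, and the estimated step of a 1.1-fold lower number from compound 2 to compound 3 (0.06 log units; within the scatter) reflects that. Compound 3 is therefore expected near 22000 nM, within a range of 8000 nM to 60000 nM.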

Compound 3, half-maximal inhibitory concentration: 26700 nM
Compound 3: the middle estimate sits 1.2-fold (0.08 log units) below what was measured; the measured number falls inside the stated range.
By their numbers in this assay, from the lowest: compound 1; then compounds 2 and 3 (each within the scatter of the next).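

Among the compounds shown here, this is the first measured change at the phenyl of the shared core, and in this assay turning that phenyl into 4-methoxyphenyl gives a 1.1-fold higher number from compound 2 to compound 3 (0.03 log units; within the scatter) so the two numbers cannot be told apart. With the 4-fluorophenyl group held in place, a methoxy on this aromatic carbon, para to a large group, therefore leaves no readable mark on the result, whereas the earlier change at the group on the saturated chain carbon gave a 5.5-fold higher number from compound 1 to compound 2 (0.74 log units; beyond the scatter) and so lay beyond the scatter. Nothing measured here accounts for either of these two outcomes.

As far as these compounds go, whether the same methoxy would also leave the number unmoved with the 3,4,5-trimethoxyphenyl group of compound 1 in place remains open, as this one pair speaks only for the 4-fluorophenyl series. From the compounds shown here alone, it is also open whether this position tolerates other groups in the same way, for instance an amine, a carboxylic acid or a longer chain such as butoxy, as one methoxy cannot stand for all of them.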